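The source may hold more compounds than are shown below. What is called first, only, known or untested is meant among the compounds shown, and "the series" means these compounds.

Compound 1 `O=C(Nc1cccc(F)c1)N[C@H]1CC[C@H](Oc2ccc(F)cc2)CC1`, compound 2 `O=C(Nc1ccccc1Cl)N[C@H]1CC[C@H](Oc2ccc(F)cc2)CC1` and compound 3 `O=C(Nc1cccc(Br)c1)N[C@H]1CC[C@H](Oc2ccc(F)cc2)CC1` share one core and differ only in the group carried on the amide-type nitrogen. In a functional assay on CRL2813 cells (Homo sapiens) for cytotoxicity, read by sulforhodamine B assay, with a stated time of 5 days (on this read-out higher numbers stand for weaker inhibition and lower numbers for stronger inhibition), compound 1 gives 8300 nM, compound 2 gives 9100 nM and compound 3 gives 6200 nM, the lowest of the three, though all three sit within the scatter of one another: a 1.3-fold lower number from compound 1 to compound 3 (0.13 log units; within the scatter) and a 1.5-fold lower number from compound 2 to compound 3 (0.17 log units; within the scatter). Compound 4 `COc1cccc(NC(=O)N[C@H]2CC[C@H](Oc3ccc(F)cc3)CC2)c1` carries methoxy in place of bromo on an aromatic carbon. Among the compounds with values here, the only earlier change on an aromatic carbon of this ring is a 1.3-fold lower number from compound 1 to compound 3 (0.13 log units; within the scatter), and no methoxy has been measured here, so nothing points to a move beyond the scatter. A step of a 1.0-fold higher number from compound 3 to compound 4 (0.02 log units; within the scatter) is therefore expected. Compound 4 is estimated at 6500 nM, ranging from 3500 nM to 12000 nM.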

Compound 4, half-maximal inhibitory concentration: 14000 nM
Compound 4: middle estimate off by 2.2-fold (0.33 log units), on the low side, outside the stated range (above it).
By their numbers in this assay, from the lowest: compounds 3, 1, 2 and 4 (each within the scatter of the next, the first and the last beyond it).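

In this assay, swapping bromo for methoxy gives the only step among these compounds that lies beyond the scatter: a 2.3-fold higher number from compound 3 to compound 4 (0.35 log units; beyond the scatter). The other two steps to the 3-methoxyphenyl group stay within it: a 1.7-fold higher number from compound 1 to compound 4 (0.23 log units; within the scatter) and a 1.5-fold higher number from compound 2 to compound 4 (0.19 log units; within the scatter). So the group on this aromatic carbon can shift the number, but only the bromo and methoxy pair separates clearly, and no evidence here accounts for that gap. On these data alone, whether an amine, a carboxylic acid or a longer chain on this carbon would raise the number further or lower it stays open.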